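A few compounds are considered here, and "the series" means these few. Any claim that something is new, unique, unknown or untested is made for them only; others in the source may bear on it.

Measured compounds:
Compound 1 `COC(=O)/C(=C\c1c(-c2ccccc2)[nH]c2ccccc12)S(=O)(=O)c1ccccc1` gives 1000 nM in a functional assay on MT4 cells (Homo sapiens) for antiproliferative activity, read by MTT assay, with a stated time of 96 h; on this read-out higher numbers stand for an effect only at larger amounts of compound and lower numbers for an effect already at smaller amounts.
Compound 2 `CCOC(=O)/C(=C/c1c(-c2ccccc2)[nH]c2ccccc12)C(=O)c1ccccc1` gives 7000 nM in this assay.
Compound 3 `O=C(/C(=C\c1c(-c2ccccc2)[nH]c2ccccc12)S(=O)(=O)c1ccccc1)c1ccccc1` gives 3000 nM in this assay.

Among these three, compound 3 holds the second-highest number: compound 1 lies beneath it by a 3.0-fold higher number from compound 1 to compound 3 (0.48 log units; beyond the scatter), and compound 2 lies above it by a 2.3-fold lower number from compound 2 to compound 3 (0.37 log units; beyond the scatter). Both gaps sit beyond the scatter.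

Compound 4 `CC(=O)/C(=C/c1c(-c2ccccc2)[nH]c2ccccc12)C(=O)c1ccccc1` has not yet been measured in this assay. It differs from compound 3 in one place: acetyl in place of phenylsulfonyl on a double-bonded chain carbon bound to a carbonyl carbon and a double-bonded chain carbon.

Among the compounds with values here, the step that bears most directly on this change is the one from compound 2 to compound 3, where a phenylsulfonyl replaced an ethoxycarbonyl on the same double-bonded chain carbon and the number fell by a 2.3-fold lower number from compound 2 to compound 3 (0.37 log units; beyond the scatter). Compound 4 moves the other way, taking the phenylsulfonyl off again and putting a small acetyl in its place. The pair of compounds 1 and 3 changes a different position and only sets the spread of the series. With the phenylsulfonyl gone, a modest rise in the number is expected for compound 4, of about a 1.7-fold higher number from compound 3 to compound 4 (0.22 log units; within the scatter). Compound 4 is therefore estimated at 5000 nM in this assay, with a likely range from 1500 nM to 15000 nM.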

Compound 4, half-maximal effective concentration: 2000 nM
Compound 4: the middle estimate sits 2.5-fold (0.40 log units) above what was measured; low and high end bracket the measured number.
By their numbers in this assay, from the lowest: compounds 1, 4 and 3 (each within the scatter of the next, the first and the last beyond it); then compound 2.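

In this assay, the step of a 1.5-fold lower number from compound 3 to compound 4 (0.18 log units; within the scatter) shows that this double-bonded chain carbon tolerates the exchange of phenylsulfonyl for acetyl without a readable difference, even though the change removes the six-membered aromatic ring and leaves 3 heavy atoms where there were 9. The step of a 3.5-fold lower number from compound 2 to compound 4 (0.54 log units; beyond the scatter), which replaces ethoxy with methyl on a carbonyl carbon, adds a second comparison: compound 2, with its ethoxycarbonyl, now stands apart from both compound 3 and compound 4, so the earlier drop from compound 2 to compound 3 did not depend on phenylsulfonyl specifically. Nothing available explains either step.

Going by these compounds, whether this tolerance extends to a carboxylic acid, an amine-bearing chain or a longer acyl chain on this double-bonded chain carbon remains open, as the acetyl and phenylsulfonyl groups are the only two that can be compared here without the ethoxycarbonyl. On these data alone, it is also open whether the same steps would hold on a different core or when the benzoyl group shared by compound 2, compound 3 and compound 4 is replaced.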